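Azetidinyl to piperidinyl on the double-bonded ring carbon

The source may hold more compounds than are shown below. What is called first, only, known or untested is meant among the compounds shown, and "the series" means these compounds.

Compound 1 `O=C1C=C(N2CCC2)C(=O)c2c1nc1n2[C@H]2OC[C@@H](O)[C@H]2OC1` is tested in a functional assay on MCF7 cells (Homo sapiens) for inhibition, read by sulforhodamine B assay; a higher number here means a weaker inhibitor, a lower number a stronger inhibitor. Compound 1 gives only a limit there, > 16000 nM, so its place on the scale is not fixed; it sits at the limit of > 16000 nM in this assay, at which 1 of the 2 values shown sits. Compound 2 `COc1cccc(NC2=CC(=O)c3c(nc4n3[C@H]3OC[C@@H](O)[C@H]3OC4)C2=O)c1`, a differently substituted member of the same series, gives 3830 nM in this assay. Going by the values given here, no step between measured compounds connects these two, so their values can only be set side by side: compound 2 falls within the measured range, compound 1 does not.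

Compound 3 `O=C1C=C(N2CCCCC2)C(=O)c2c1nc1n2[C@H]2OC[C@@H](O)[C@H]2OC1` has not yet been measured. The change from compound 1 is piperidin-1-yl in place of azetidin-1-yl on a double-bonded ring carbon. Among the compounds with values here, no measured step of this kind is available, so the size of the effect is open. A modest shift toward stronger inhibition is plausible, yet the expectation is that compound 3 remains near the weak end of this assay. The estimate for compound 3 is 12000 nM, expected to lie within 3000 nM to 40000 nM. This corresponds to an expected step of an at least 1.3-fold lower number from compound 1 to compound 3 (0.12 log units; that floor lies within the scatter), with a fair chance that the assay again reports only a limit.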

Compound 3, half-maximal inhibitory concentration: > 8000 nM
Compound 3 ended at the assay's limit; the forecaster's own chance of this, stated with the estimate: 50%; the middle value is on the limit's open side.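

In this assay compound 1 gives only a limit, > 16000 nM. Going by these compounds alone, compound 3 also gives only a limit, > 8000 nM, so no step between compound 1 and compound 3 can be read. The compounds shown leave open whether piperidin-1-yl in place of azetidin-1-yl on a double-bonded ring carbon changes inhibition at all.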